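Ethyl ester kept, fluoro exchanged for sec-butoxy

The source may report more compounds than this note shows. Statements on the series, on what has been measured and on what is new or still open speak of the compounds shown alone.

Of the compounds shown here, three built on a shared core have been tested in a functional assay on the whole organism (strain Sprague-Dawley) for inhibition, with Rattus norvegicus as the target, with a stated time of 10 min; a lower number here means that less compound is needed, a higher number that more compound is needed for the effect. Compound 1 `O=C(O)c1cnc(-c2ccccc2F)[nH]c1=O` gives 5 mg/kg. Among the compounds with values here, compound 2 `CCOc1cccc(-c2ncc(C(=O)O)c(=O)[nH]2)c1` gives 5 mg/kg, which lies within the scatter of compound 1; the two differ in more than one place, so no single step joins them. Compound 3 `CCOC(=O)c1cnc(-c2ccccc2F)[nH]c1=O` reaches only a limit of this assay, > 10 mg/kg, and not a number. Within the data shown here, the one measured step, an at least 2.0-fold higher number from compound 1 to compound 3 (0.30 log units; that floor lies within the scatter), comes from ethyl in place of hydrogen on an oxygen next to a carbonyl group, and its reading rests on (the limit of > 10 mg/kg in this assay, at which 1 of the 3 values shown sits).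

Compound 4 `CCOC(=O)c1cnc(-c2ccccc2OC(C)CC)[nH]c1=O` keeps the ethyl ester of compound 3 and differs from it by sec-butoxy in place of fluoro on an aromatic carbon. Among the measured compounds shown here, no measured step covers an exchange of fluoro for an alkoxy group on this ring, so the only guide is that the ester already sits at a limit. The expected step is a step that the limit leaves unreadable from compound 3 to compound 4, no larger than the scatter. Compound 4 is therefore estimated at 15 mg/kg, with a range from 5 mg/kg to 45 mg/kg.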

Compound 4, dose for 50% inhibition: 0.5 mg/kg
The estimate for compound 4 lay 30-fold (1.48 log units) above the measured number, and the stated range ends above it.
By their numbers in this assay, from the lowest: compound 4; then compounds 1 and 2 (each within the scatter of the next). At a limit, above all of these: compound 3.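

Sec-butoxy in place of fluoro on an aromatic carbon, ortho to a large group, brings in this assay an at least 20-fold lower number from compound 3 to compound 4 (1.30 log units; beyond the scatter). Compound 3 showed the ethyl ester only at a limit. Compound 4 gives 0.5 mg/kg while keeping that ester, so the ester does not rule out a low dose and the group on this ring carbon can change the result strongly. The step size is only a floor, and its reading rests on a limit: the limit of > 10 mg/kg in this assay, at which 1 of the 4 values shown sits.

Still open, from the compounds shown here alone, is whether this drop belongs to sec-butoxy itself or would also come with a shorter group such as methoxy, or with a hydroxyl group, on the same carbon. Also open, going by these compounds, is whether the carboxylic acid of compound 1 would respond to sec-butoxy in the same way as the ester.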